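The source may report more compounds than this note shows. Statements on the series, on what has been measured and on what is new or still open speak of the compounds shown alone.

Compound 2 `COC(=O)/C=C/c1cccc(N(Cc2ccc(C(C)(C)C)cc2)C(=O)C2CCCCC2)c1` is the starting point of this step. In an assay on isolated protein with Bile acid receptor (Homo sapiens) as the target (a higher number here means that more compound is needed for the effect, a lower number that less compound is needed), compound 2 gives > 1000 nM, which is a limit of the assay and not a number. Compound 1 `COC(=O)/C=C/c1cccc(N(Cc2ccccc2Br)C(=O)C2CCCCC2)c1` is measured in this assay at > 1000 nM, again a limit and not a number. Compound 3 `COC(=O)/C=C/c1cccc(N(Cc2cccc(OC)c2)C(=O)C2CCCCC2)c1` is measured in this assay at > 1000 nM, also a limit. The steps a step that the two limits leave unreadable from compound 1 to compound 2, a step that the two limits leave unreadable from compound 1 to compound 3 and a step that the two limits leave unreadable from compound 2 to compound 3 therefore carry no readable size. What the measured set shows is the limit of > 1000 nM in this assay, at which 3 of the 3 values shown sit. Compound 4 `COC(=O)/C=C/c1cccc(N(Cc2ccc(-c3cccc(OC(F)(F)F)c3)cc2)C(=O)C2CCCCC2)c1` differs from compound 2 in one place: 3-(trifluoromethoxy)phenyl in place of tert-butyl on an aromatic carbon. Within the data shown here, none of the measured steps touches this change, and none has a readable size, so neither direction nor magnitude can be taken from them for this assay; the change is larger than any of the measured swaps and adds a ring. The step from compound 2 to compound 4 is estimated at a step that the limit leaves unreadable from compound 2 to compound 4 in this assay. For compound 4 the expected value in this assay is 1500 nM, with a range from 300 nM to 8000 nM.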

Compound 4, half-maximal effective concentration: 420 nM
Estimate against measurement, compound 4: 3.6-fold (0.55 log units) above, and the stated range covers the measured number.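

In this assay, among these compounds, 3-(trifluoromethoxy)phenyl in place of tert-butyl gives an at least 2.3-fold lower number from compound 2 to compound 4 (0.37 log units; beyond the scatter), the only readable step, since the steps among compound 1, compound 2 and compound 3 cannot be read. The aromatic carbon para to a large group thus accepts a six-membered aromatic ring of carbon only, and the entering group of 11 heavy atoms against 4 goes with a lower number rather than a loss. Compound 4 alone comes off the limit that holds the other compounds shown: the limit of > 1000 nM in this assay, at which 3 of the 4 values shown sit.

Open, as far as these compounds go, is whether a plain phenyl at this place would give the same number, so the shares of the added ring and of the trifluoromethoxy group remain unknown. Also open, from the compounds shown here alone, is what a carboxylic acid in place of the methyl ester would do to the number of compound 4.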